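Furan-3-yl to thiophen-2-yl on the shared core

The source may hold more compounds than are shown below. What is called first, only, known or untested is meant among the compounds shown, and "the series" means these compounds.

Measured so far in a functional assay on MT2 cells (Homo sapiens) for cytotoxicity, read by MTT assay; a lower number here means that less compound is tolerated, a higher number that more compound is tolerated:
compound 1 `CC(C)=CCOc1cc(Nc2nccs2)ccc1Cl` gives 26000 nM
compound 2 `CCc1ccc(Nc2nccs2)cc1OCC=C(C)C` gives 31000 nM
compound 3 `Clc1ccc(Nc2nccs2)cc1OCc1ccoc1` gives 26000 nM

Compound 3 stands level with compound 1 at the digits available, and compound 2 lies within the scatter of both, so the three values form a single level. Compound 4 `Clc1ccc(Nc2nccs2)cc1OCc1cccs1` has not yet been measured. It differs from compound 3 as follows: thiophen-2-yl in place of furan-3-yl on a saturated chain carbon bound to an oxygen on an aromatic ring. The swap is thiophen-2-yl in place of furan-3-yl on a saturated chain carbon bound to an oxygen on an aromatic ring.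

The closest evidence is no change at the digits printed from compound 1 to compound 3 (within the scatter), a change at this same place, from 2-methylprop-1-en-1-yl to furan-3-yl. The other measured step, a 1.2-fold higher number from compound 1 to compound 2 (0.08 log units; within the scatter), puts ethyl in place of chloro and bears on the swap only loosely. For the measured compounds named here, both stay within the scatter, although no measured compound carries thiophen-2-yl. No step beyond the scatter is therefore expected in this assay. The expected step is no change at the digits printed from compound 3 to compound 4 (within the scatter). For compound 4 the estimated value is 26000 nM, with an expected range from 14000 nM to 45000 nM.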

Compound 4, half-maximal cytotoxic concentration: 38000 nM
The estimate for compound 4 lay 1.5-fold (0.16 log units) below the measured number; low and high end bracket the measured number.
By their numbers in this assay, from the lowest: compounds 1, 3, 2 and 4 (each within the scatter of the next).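

In this assay thiophen-2-yl in place of furan-3-yl gives a 1.5-fold higher number from compound 3 to compound 4 (0.16 log units; within the scatter) and thiophen-2-yl in place of 2-methylprop-1-en-1-yl gives a 1.5-fold higher number from compound 1 to compound 4 (0.16 log units; within the scatter) so a sulfur-bearing five-membered aromatic ring is now seen on the saturated chain carbon, with no step beyond the scatter. The ring hetero atom and the point of attachment change together in this swap, and the compounds shown cannot separate the two. No supporting measurement bears on why the numbers stay at one level.

On these data alone, whether any group at this place can move the number beyond the scatter remains open. An amine or a carboxylic acid in place of the five-membered aromatic ring, or a longer chain, could test this, and the compounds shown do not predict the outcome.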